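Opening the Ring: From Compound 3 to Compound 4

The source may hold more compounds than are shown below. What is called first, only, known or untested is meant among the compounds shown, and "the series" means these compounds.

The compounds here share one core and differ only in the group attached to a nitrogen on an aromatic ring. Compound 1 `CSc1nc(-c2ccc(F)cc2)c(-c2ccnc(NC3CCOCC3)c2)[nH]1` carries its own variant of that group; in a functional assay on blood (Homo sapiens) for inhibition (a higher number here means a weaker inhibitor, a lower number a stronger inhibitor), compound 1 gives "not determined" (no result reported). Compound 2 `CSc1nc(-c2ccc(F)cc2)c(-c2ccnc(NCCC(C)(C)C)c2)[nH]1` carries another variant; in this assay compound 2 gives "not determined" (no result reported). Neither of these two has a number. Within the data shown here, compound 3 `CSc1nc(-c2ccc(F)cc2)c(-c2ccnc(NC3CCCCC3C)c2)[nH]1` is the one compound with a result: in this assay compound 3 gives 136 nM. With no second number beside it, compound 3 stands alone; it cannot be called strong or weak by comparison, only placed as the single point of reference.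

Compound 4 `CCC(C)CNc1cc(-c2[nH]c(SC)nc2-c2ccc(F)cc2)ccn1` differs from compound 3 in one place: 2-methylbutyl in place of 2-methylcyclohexyl on a nitrogen on an aromatic ring. The group that enters has no ring and fewer heavy atoms, as the count shows, while donors, acceptors and charge are unchanged.

Among the measured compounds shown here, no measured pair tells what such a change does here, so any expectation rests on compound 3 alone. The expected step is a 1.9-fold higher number from compound 3 to compound 4 (0.28 log units; within the scatter), a modest weakening that may barely exceed the usual scatter. Compound 4 is estimated at 260 nM, within a range from 80 nM to 850 nM.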

Compound 4, half-maximal inhibitory concentration: 2760 nM
For compound 4 the middle estimate is 11-fold (1.03 log units) below the measured one; measured number outside the range, above it.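

In this assay, opening the ring gives a 20-fold higher number from compound 3 to compound 4 (1.31 log units; beyond the scatter), a large step that shows this place on the nitrogen is sensitive to the group it carries. Neither 2-methylcyclohexyl nor 2-methylbutyl has hydrogen-bond donors, hydrogen-bond acceptors or a net charge, so this large loss comes with a change in carbon groups alone: the ring goes and the heavy-atom count falls. Nothing available here explains why the step is so large.

Still open, going by these compounds, is whether the ring itself or the number of carbons matters more; a plain cyclohexyl group or a longer open chain such as heptyl would help separate the two. Also open, on these data alone, is how a ring carrying a hydroxyl group or an amine would behave at this place.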